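Nitrone triazoles: benzyl to tert-butyl at the nitrone nitrogen

The compounds below may be only part of what the source reports. "The series", "measured", "known", "first", "only" and "open" are said of these compounds alone.

Measured so far:
compound 1, `[O-]/[N+](=C\c1cn(CCC(F)(F)C(F)(F)C(F)(F)C(F)(F)C(F)(F)C(F)(F)F)nn1)Cc1ccccc1`: > 100000 nM in a functional assay on A549 cells (Homo sapiens) for inhibition, read by MTT assay, with a stated time of 24 h; on this read-out higher numbers stand for weaker inhibition and lower numbers for stronger inhibition
compound 2, `[O-]/[N+](=C\c1cn(CCC(F)(F)C(F)(F)C(F)(F)C(F)(F)C(F)(F)C(F)(F)C(F)(F)C(F)(F)F)nn1)Cc1ccccc1`: 8800 nM in this assay

Compound 1 stands only at a limit in this assay: the value > 100000 nM is the upper limit of the read-out and not a number, as noted in the limit of > 100000 nM in this assay, at which 1 of the 2 values shown sits. Compound 2 gives a number, 8800 nM, and the step of an at least 11-fold lower number from compound 1 to compound 2 (1.05 log units; beyond the scatter) comes from lengthening the fluorinated chain alone; the nitrone substituent is the same in both.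

Compound 3, `CC(C)(C)/[N+]([O-])=C/c1cn(CCC(F)(F)C(F)(F)C(F)(F)C(F)(F)C(F)(F)C(F)(F)F)nn1`, is not yet measured. It differs from compound 1 in tert-butyl in place of benzyl on a double-bonded nitrogen. Within the data shown here, the only measured step changes the chain and leaves the nitrone nitrogen untouched, so no measured step bears on the exchange of benzyl for tert-butyl. Because compound 1 sits at the limit > 100000 nM, the outcome for compound 3 is expected to be near that limit, with a fair chance that only a limit is returned again. The estimated step of a number no higher from compound 1 to compound 3 (the limit leaves the size open) is therefore expected to be small. Compound 3 is estimated at 100000 nM, within 30000 nM to 300000 nM.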

Compound 3, half-maximal inhibitory concentration: 11500 nM
The estimate for compound 3 lay 8.7-fold (0.94 log units) above the measured number; measured number below the stated range.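

Exchange of benzyl for tert-butyl on the double-bonded nitrogen is the first measured change at this position, and in this assay it gives an at least 8.6-fold lower number from compound 1 to compound 3 (0.93 log units; beyond the scatter). The read-out therefore responds to the substituent on the nitrone nitrogen as well as to the fluorinated chain: with the chain of compound 1 held constant, tert-butyl gives a measured number where benzyl gives only a limit. The step has a minimum size and no fixed size, as the value for compound 1 is a limit and not a number: the limit of > 100000 nM in this assay, at which 1 of the 3 values shown sits.

Whether tert-butyl combined with the longer fluorinated chain of compound 2 would lower the number further remains open, so the compounds shown cannot tell whether the chain and nitrogen changes add together or act independently. Among these compounds, the single exchange also leaves open whether the gain follows from removing benzyl or is particular to tert-butyl, a question that other groups on this nitrogen, such as isopropyl, cyclohexyl or a benzyl carrying a carboxylic acid, would address.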